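The compounds below may be only part of what the source reports. "The series", "measured", "known", "first", "only" and "open" are said of these compounds alone.

Measured so far:
- compound 1, `CCCCNC(=O)N1CC1C#N`: 17000 nM in a functional assay on RPMI-8226 cells (Homo sapiens) for inhibition; a higher number here means a weaker inhibitor, a lower number a stronger inhibitor
- compound 2, `N#CC1CN1C(=O)Nc1ccc(C(F)(F)F)cc1`: 7800 nM in this assay

Compound 1 has the highest number of the two in this assay; compound 2 is the nearer of the pair, with a number lower by more than the scatter. Among the measured compounds shown here, no step between measured compounds that differ in one place is known, so the pair gives only their two values and no isolated effect of any single change.

Compound 3, `CCNC(=O)N1CC1C#N`, is not yet measured. It differs from compound 1 by hydrogen in place of ethyl on a saturated chain carbon, two bonds along the chain from an amide-type nitrogen. For the measured compounds named here, no measured step of this kind exists, so the size and direction of the change are open. The expectation is a modest shift in this assay towards a higher number, within or only slightly beyond the scatter: the step from compound 1 to compound 3 is estimated as a 1.5-fold higher number from compound 1 to compound 3 (0.17 log units; within the scatter). Compound 3 is therefore expected to give about 25000 nM in this assay, with a range from 8000 nM to 80000 nM.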

Compound 3, half-maximal inhibitory concentration: 26000 nM
The estimate for compound 3 lay 1.0-fold (0.02 log units) below the measured number, and the stated range covers the measured number.
By their numbers in this assay, from the lowest: compound 2; then compounds 1 and 3 (each within the scatter of the next).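

In this assay the series now has its first single-change step: hydrogen in place of ethyl on a saturated chain carbon, two bonds along the chain from an amide-type nitrogen, gives a 1.5-fold higher number from compound 1 to compound 3 (0.18 log units; within the scatter) and so does not separate the butyl chain of compound 1 from the ethyl chain of compound 3. At this position, the removal of two chain carbons therefore leaves the read-out within the usual scatter, which the earlier pair could not show. Nothing available explains this result.

From the compounds shown here alone, whether a longer chain, such as octyl, would move the number beyond the scatter remains open. So does the outcome of placing an amine or a carboxylic acid on the chain at this position.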